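Benzylsulfanyl in Place of Benzylamino on a Nucleoside Core

A few compounds are considered here, and "the series" means these few. Any claim that something is new, unique, unknown or untested is made for them only; others in the source may bear on it.

Compound 1, `OC[C@H]1O[C@@H](n2cnc3c(NCc4ccccc4)nccc32)C[C@@H]1O`: 15%
Compound 2, `[N-]=[N+]=Nc1nccc2ncn([C@H]3C[C@H](O)[C@@H](CO)O3)c12`: 14%
Compound 3, `Sc1[nH]ccc2ncnc1-2`: 26%

All three were measured in a functional assay (Homo sapiens) for inhibition of Nucleic Acid, tested at 100 uM; a lower number here means less inhibition, a higher number more inhibition at the concentration tested (going by the name of the read-out). Compound 1 gives 15% there, and compound 2 gives 14%; the two numbers lie within the scatter of one another, so nothing separates them. Compound 3, a smaller compound without the sugar, gives 26%, which stands above compound 1 by a margin beyond the scatter. Among the three, compound 1 thus sits below compound 3 and level with compound 2, and all three numbers are low.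

The compound that follows is compound 4, `OC[C@H]1O[C@@H](n2cnc3c(SCc4ccccc4)nccc32)C[C@@H]1O`. It differs from compound 1 in one place: benzylsulfanyl in place of benzylamino on an aromatic carbon

No measured pair among these three shows such an exchange, so the data give no measured step to lean on for this change. Since compound 1 and compound 2, which differ in the group on the same aromatic carbon, give numbers within the scatter of each other, the step from compound 1 to compound 4 is expected to be small, a number 1 percentage points higher from compound 1 to compound 4 (within the scatter), or none beyond the scatter in either direction.

Compound 4 is therefore estimated at 16% in this assay, with a range from 2% to 34%.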

Compound 4, a percentage reported as inhibition, at one concentration (the size of the read-out at that concentration, not a potency): 18%
Compound 4: middle estimate off by 2 percentage points, on the low side, and the stated range covers the measured number.
By their numbers in this assay, from the lowest: compounds 2, 1, 4 and 3 (each within the scatter of the next, the first and the last beyond it).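

In this assay, among these compounds, the exchange of benzylamino for benzylsulfanyl on an aromatic carbon, next to the ring nitrogen, gives a number 3 percentage points higher from compound 1 to compound 4 (within the scatter), and this is the first measured step in which only this group changes. The exchange replaces nitrogen with sulfur in the link to the benzyl group and takes the count of hydrogen-bond donors in the group from 1 to 0, yet the numbers for the two compounds cannot be told apart, so this pair shows no sign that either the linking atom or that donor changes the read-out at this position. Nothing measured here bears on why the two compounds read alike, and no explanation can be offered from these data.

What the compounds shown leave open is whether any other group on this aromatic carbon, such as benzyloxy, a free amine or a longer phenylethylamino chain, would stand apart from compound 1 by more than the scatter. They also leave open whether a substituent on the benzyl ring itself, such as a chlorine or a methoxy group, would change the low inhibition seen in compound 1 and compound 4.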